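Adding One Hydroxy Group to Compound 3

The source may hold more compounds than are shown below. What is called first, only, known or untested is meant among the compounds shown, and "the series" means these compounds.

- Compound 1 `COc1cc2c(/C=C3/C(=O)Nc4cc(Cl)ccc43)c(Cl)[nH]c2cc1C`: 230 nM
- Compound 2 `COc1cc2c(/C=C3/C(=O)Nc4ccc(Br)cc43)c(Cl)n(C)c2cc1C`: 1550 nM
- Compound 3 `COc1cc2c(/C=C3/C(=O)N(C)c4ccccc43)c[nH]c2cc1C`: 3090 nM

All three compounds were tested in a functional assay on cells (Melanoma cell, Homo sapiens) for inhibition, with a stated time of 48 h; a lower number here means a stronger inhibitor of growth, a higher number a weaker inhibitor of growth. Compound 3 and compound 2 lie within the usual scatter of each other, so the two count as level. Compound 1, at 230 nM, has a clearly lower number than compound 3 at 3090 nM. Compound 3 therefore stands at the weak end of this small set, alongside compound 2.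

The next compound is compound 4 `COc1cc2c(/C=C3/C(=O)N(C)c4ccc(O)cc43)c[nH]c2cc1C`. It keeps all of compound 3 except for one place: hydroxy in place of hydrogen on an aromatic carbon. In words, this is hydroxy in place of hydrogen on an aromatic carbon.

Among the compounds with values here, no measured pair here differs in a single place, so the data give no direct size for such a change. Compound 1 and compound 2 each differ from compound 3 in several places at once, and their values cannot be credited to any one group. With compound 3 at 3090 nM as the starting point, only a small expected shift toward a lower number in this assay seems reasonable, probably none beyond the scatter.

The expected change is a 1.5-fold lower number from compound 3 to compound 4 (0.19 log units; within the scatter). For compound 4 the estimated value is 2000 nM, with an expected range from 600 nM to 6000 nM.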

Compound 4, concentration for 50% growth inhibition: 3240 nM
Compound 4: middle estimate off by 1.6-fold (0.21 log units), on the low side; low and high end bracket the measured number.
By their numbers in this assay, from the lowest: compound 1; then compounds 2, 3 and 4 (each within the scatter of the next, the first and the last beyond it).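

In this assay, hydroxy in place of hydrogen on an aromatic carbon gives a 1.0-fold higher number from compound 3 to compound 4 (0.02 log units; within the scatter), so compound 3 and compound 4 count as level. Within the data shown here, this is the first pair in the set that differs in only one place, and so the first direct reading of a single change: at this carbon, meta to a fused ring and para to a fused ring, adding a hydroxy group, with its one hydrogen-bond donor and one hydrogen-bond acceptor, produces no shift that can be told apart from the ordinary spread of repeated measurements. No measured information is available to explain this result.

As far as these compounds go, it remains open whether a different group on this same carbon, such as an amine, a carboxylic acid or a longer chain, would also leave the number level, or whether this flat reading belongs to hydroxy alone. Among these compounds, it is also open whether hydroxy would give the same result on another carbon of this ring, or on a core that differs from the one shared by compound 3 and compound 4.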